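Ethylsulfanyl against methylsulfanyl on the shared core

A few compounds are considered here, and "the series" means these few. Any claim that something is new, unique, unknown or untested is made for them only; others in the source may bear on it.

Of the compounds shown here, two have been measured in a functional assay on the whole organism (strain Sprague-Dawley) with Rattus norvegicus as the target, read by paw edema, with a stated time of 3 h, at a dose of 50 mg/kg by the oral route; on this read-out lower numbers stand for less inhibition and higher numbers for more inhibition at the one dose given (going by the name of the read-out). Compound 1 `CCSc1ncc(-c2ccc(S(C)(=O)=O)cc2)n1-c1ccc(F)cc1` gives 65%. Compound 2 `CSc1ncc(-c2ccc(S(C)(=O)=O)cc2)n1-c1ccc(Cl)cc1` gives 59.5%. Of the two numbers, compound 2 holds the one that stands lower on paper, but the gap to compound 1 is within the usual scatter, so no order between compound 1 and compound 2 is claimed. Going by the values given here, compound 1 and compound 2 differ in more than one place, so no single step between measured compounds is available.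

Compound 3 `CCSc1ncc(-c2ccc(S(C)(=O)=O)cc2)n1-c1ccc(Cl)cc1` is not yet measured. It is reached from compound 2 by the change (methyl in place of hydrogen on a saturated chain carbon bound to a sulfur). With no measured step of this kind in the series, the expectation for this change rests only on the two numbers above, which sit close together and do not point in either direction. For this assay the step from compound 2 to compound 3 is expected to be a number 2.5 percentage points higher from compound 2 to compound 3 (within the scatter), that is, none beyond the scatter. Compound 3 is therefore estimated at 62%, within a range from 48% to 76%.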

Compound 3, a percentage reported as inhibition, in the whole organism at one dose (the size of the read-out at that dose, not a potency): 53.8%
Estimate against measurement, compound 3: 8.2 percentage points above; measured number inside the range.
By their numbers in this assay, from the lowest: compounds 3, 2 and 1 (each within the scatter of the next, the first and the last beyond it).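

In this assay, methyl in place of hydrogen on a saturated chain carbon bound to a sulfur gives a number 5.7 percentage points lower from compound 2 to compound 3 (within the scatter) with chloro held constant, so this first single-place reading of methylsulfanyl to ethylsulfanyl shows no separation between the two chains at this dose. Going by these compounds alone, with ethylsulfanyl held constant, chloro in place of fluoro on an aromatic carbon gives a number 11.2 percentage points lower from compound 1 to compound 3 (beyond the scatter) and is a modest step, which makes the halogen change the only one of the two so far to separate compounds beyond the usual scatter, on the strength of a single pair. Nothing in hand bears on why either step has the size it has.

Open is whether a longer chain such as propylsulfanyl, or an amine in place of the alkylsulfanyl group, would stay within the scatter of the two chains shown or move the number clearly. Also open, going by these compounds, is whether chloro in place of fluoro gives a step of similar size with methylsulfanyl on the shared core, as the fluoro step is so far read with ethylsulfanyl alone.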